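The compounds below may be only part of what the source reports. "The series", "measured", "known", "first", "only" and "open" are said of these compounds alone.

Of the compounds shown here, two have been measured for antiproliferative activity on HCC78 cells. Compound 1, `CC(Oc1cccnc1Nc1cnn(C)c1)c1cccc(C(=O)NCc2ccc(Cl)c(C(F)(F)F)c2)c1`, gives 48600 nM in a functional assay on HCC78 cells (Homo sapiens) for antiproliferative activity, read by MTT assay, with a stated time of 48 h; on this read-out higher numbers stand for weaker inhibition and lower numbers for stronger inhibition. Compound 2, `Cc1ccc(CNC(=O)c2cccc(C(C)Oc3ccnc(Nc4cnn(C5CCN(C)CC5)c4)c3)c2)cc1`, gives 8100 nM in this assay, the lower of the two numbers; the gap to compound 1 lies beyond the usual scatter, but the two structures differ in more than one place, so the comparison does not isolate any single change.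

Compound 3, `CC(Oc1ccnc(Nc2cnn(C3CCN(C)CC3)c2)c1)c1cccc(C(=O)NCc2ccc(Cl)c(C(F)(F)F)c2)c1`, has not yet been measured. It keeps the core of compound 2 and carries the change (4-chloro-3-(trifluoromethyl)phenyl in place of 4-methylphenyl on a saturated chain carbon bound to an amide-type nitrogen), so that its amide side chain matches that of compound 1 while its core matches that of compound 2. Among the compounds with values here, no measured pair in the set isolates this exchange, and the only bearing of compound 1 on it is indirect.

Because compound 2 stands at 8100 nM, the expectation is a modest step from compound 2 to compound 3 toward stronger inhibition, a 2.7-fold lower number from compound 2 to compound 3 (0.43 log units; beyond the scatter), though a result within the scatter would not be surprising. Compound 3 is therefore estimated at 3000 nM in this assay, within a range from 800 nM to 12000 nM.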

Compound 3, half-maximal inhibitory concentration: 7300 nM
Compound 3: middle estimate off by 2.4-fold (0.39 log units), on the low side, and the stated range covers the measured number.
By their numbers in this assay, from the lowest: compounds 3 and 2 (each within the scatter of the next); then compound 1.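

In this assay the set gains its first comparison that differs in one place: 4-chloro-3-(trifluoromethyl)phenyl in place of 4-methylphenyl on a saturated chain carbon bound to an amide-type nitrogen gives a 1.1-fold lower number from compound 2 to compound 3 (0.05 log units; within the scatter), so on this core the two groups cannot be told apart by this read-out. The position therefore accepts a group of 11 heavy atoms, including chlorine and fluorine, in place of one of 7 carbon atoms, without a change that can be read in this assay, something the unmatched pair of compound 1 and compound 2 could not show. No measurement on hand offers a reason for this result.

As far as these compounds go, whether an amine or a carboxylic acid on the phenyl ring, or a longer chain between the amide nitrogen and that ring, would shift the number beyond the scatter remains open, as does whether the same exchange would read alike on the core of compound 1. Within the data shown here, the contributions of the chlorine and the trifluoromethyl also stay unseparated, since no compound here carries one of them alone.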